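This account rests on a few compounds, and the source may have more. Where it says the series, first, only, none or still open, it means among the compounds named here.

In a functional assay on K562 cells (Homo sapiens) for antiproliferative activity, read by MTT assay, with a stated time of 24 h (a lower number here means a stronger inhibitor, a higher number a weaker inhibitor), compound 1 `COc1ccc(C(=O)/C=C/c2ccccc2)c2c1C=CC(C)(C)O2` gives > 10000 nM, which is a limit and not a number. Compound 2 `COc1ccc(C(=O)/C=C/c2ccco2)c2c1C=CC(C)(C)O2` gives > 10000 nM, again a limit. Compound 3 `COc1ccc(C(=O)/C=C/c2ccc(O)cc2)c2c1C=CC(C)(C)O2` gives > 10000 nM, also a limit, so it has no numerical standing in the series. The three compounds share one position: the limit of > 10000 nM in this assay, at which 3 of the 3 values shown sit.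

Compound 4 `COc1ccc(C(=O)/C=C/c2cc(Cl)ccc2O)c2c1C=CC(C)(C)O2` follows from compound 3 by the change (5-chloro-2-hydroxyphenyl in place of 4-hydroxyphenyl on a double-bonded chain carbon bound to a double-bonded chain carbon). Here 5-chloro-2-hydroxyphenyl takes the place of 4-hydroxyphenyl on a double-bonded chain carbon bound to a double-bonded chain carbon.

The measured steps bearing on this place are a step that the two limits leave unreadable from compound 1 to compound 3, a step that the two limits leave unreadable from compound 2 to compound 3 and a step that the two limits leave unreadable from compound 1 to compound 2. Among the measured compounds shown here, none has a size that can be carried over, and no chlorine-bearing compound has been measured. The expected result is therefore an at least 1.2-fold lower number from compound 3 to compound 4 (0.09 log units; that floor lies within the scatter), with only a weak expected lean towards stronger inhibition in this assay, and another limit remains quite possible. For compound 4 the estimate is 8000 nM, with an expected range from 2000 nM to 20000 nM.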

Compound 4, half-maximal inhibitory concentration: 5510 nM
Compound 4: middle estimate off by 1.5-fold (0.16 log units), on the high side; measured number inside the range.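

In this assay compound 4 gives a measured number, 5510 nM, so 5-chloro-2-hydroxyphenyl is the only group shown on this double-bonded chain carbon that gives one. Compound 1, compound 2 and compound 3 share one position: the limit of > 10000 nM in this assay, at which 3 of the 4 values shown sit.

Against those limits the readable steps are an at least 1.8-fold lower number from compound 3 to compound 4 (0.25 log units; that floor lies within the scatter), an at least 1.8-fold lower number from compound 2 to compound 4 (0.25 log units; that floor lies within the scatter) and an at least 1.8-fold lower number from compound 1 to compound 4 (0.25 log units; that floor lies within the scatter). On these data alone, each is a floor only, so the real size of each step stays unknown, and none of the three floors by itself clears the scatter.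

The change from 4-hydroxyphenyl to 5-chloro-2-hydroxyphenyl alters two things at once, and the compounds shown do not separate the chlorine from the placing of the hydroxy group. Also open, as far as these compounds go, is what a bromine in place of the chlorine, or a dimethylamino group in place of the hydroxy group, would give at this place.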